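The source may hold more compounds than are shown below. What is called first, only, known or untested is meant among the compounds shown, and "the series" means these compounds.

In a functional assay on Huh-7 cells (Homo sapiens) for inhibition, read by CCK-8 assay, with a stated time of 72 h (on this read-out lower numbers stand for stronger inhibition and higher numbers for weaker inhibition), two compounds have been measured so far. Compound 1 (`O=C(/C=C/c1cccnc1)NCCCCCCCc1ccc(S(=O)(=O)Nc2ccccc2)cc1`) gives 1230 nM, and compound 2 (`Cc1ccc(C)c(NS(=O)(=O)c2cccc(CCCCCCNC(=O)/C=C/c3cccnc3)c2)c1`) gives 2.58 nM. Compound 2 therefore holds the lower of the two numbers, and the gap between them lies far beyond the usual scatter of repeated measurements.

Compound 3 (`O=C(/C=C/c1cccnc1)NCCCCCCc1cccc(S(=O)(=O)Nc2ccc(F)cc2)c1`) departs from compound 2 in one place, with 4-fluorophenyl in place of 2,5-dimethylphenyl on a sulfonamide nitrogen. The rest of the molecule stays the same. Among the compounds with values here, no measured pair of compounds shows what this exchange does, so any forecast here is uncertain.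

A move toward a higher number, meaning weaker inhibition, is expected, because compound 2 already sits at 2.58 nM, the low end of what has been seen. The estimated change is a 5.8-fold higher number from compound 2 to compound 3 (0.76 log units; beyond the scatter), probably beyond the scatter but much smaller than the gap between the two measured compounds. For compound 3, the expected value in this assay is 15 nM, with an estimated range from 3 nM to 120 nM.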

Compound 3, half-maximal inhibitory concentration: 4.28 nM
Beside the measured number, compound 3's estimate is 3.5-fold (0.54 log units) above it; measured number inside the range.
By their numbers in this assay, from the lowest: compounds 2 and 3 (each within the scatter of the next); then compound 1.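

In this assay, putting 4-fluorophenyl in place of 2,5-dimethylphenyl on a sulfonamide nitrogen gives a 1.7-fold higher number from compound 2 to compound 3 (0.22 log units; within the scatter), so this read-out does not separate the two compounds. Within the data shown here, this is the first direct view of this position, and it shows that these two differently decorated aromatic rings serve equally well here, even though both methyl groups go and a fluorine comes in within a single exchange. Nothing measured on these compounds explains why the two rings read alike.

Because the methyl groups and the fluorine changed together, this one pair cannot show what either does alone, and a compound carrying only a 4-methylphenyl or a 2-methylphenyl ring on the same nitrogen would begin to separate them. How far this position's tolerance reaches also remains open, since both groups compared are aromatic rings without hydrogen-bond donors or acceptors, and neither a ring bearing a carboxylic acid or an amine nor a simple ethyl chain in place of the ring appears among the compounds shown.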